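Swapping Methoxy for Acetyl on an Aromatic Ring

This account rests on a few compounds, and the source may have more. Where it says the series, first, only, none or still open, it means among the compounds named here.

Measured so far in a functional assay on HCT-116 cells (Homo sapiens) for inhibition, read by colorimetric assay, with a stated time of 3 days (a higher number here means a weaker inhibitor, a lower number a stronger inhibitor), as follows
Compound 1 (`O=C(CCCCCCNC(=O)C(O)C(F)(F)F)Nc1nccs1`) gives > 40000 nM as a limit and not a number
Compound 2 (`COc1ccc(NC(=O)CCCCCCNC(=O)C(O)(O)C(F)(F)F)cc1`) gives 4520 nM
Compound 3 (`O=C(CCCCCCNC(=O)C(O)(O)C(F)(F)F)Nc1cccc2ccccc12`) gives 6480 nM

Compound 2 at 4520 nM and compound 3 at 6480 nM lie within the usual scatter of repeated measurements, so neither can be ranked ahead of the other. The reading of > 40000 nM for compound 1 is a limit of the assay.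

Compound 4 (`CC(=O)c1ccc(NC(=O)CCCCCCNC(=O)C(O)(O)C(F)(F)F)cc1`) differs from compound 2 in one place, with acetyl in place of methoxy on an aromatic carbon, para to a large group (acetyl in place of methoxy on an aromatic carbon). Among the measured compounds shown here, no two measured compounds differ in only one place, so no measured step serves as a direct guide. The closeness of compound 2 and compound 3 is the only hint, so in this assay no change beyond the scatter is expected, in either direction. The expected step of a 1.1-fold higher number from compound 2 to compound 4 (0.04 log units; within the scatter) is therefore small. For compound 4 the estimated value is 5000 nM with an expected range from 2000 nM to 12000 nM in this measurement.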

Compound 4, half-maximal inhibitory concentration: 12100 nM
The estimate for compound 4 lay 2.4-fold (0.38 log units) below the measured number, and the stated range ends below it.
By their numbers in this assay, from the lowest: compounds 2, 3 and 4 (each within the scatter of the next, the first and the last beyond it). At a limit, above all of these: compound 1.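

In this assay, among the compounds shown here, the swap of methoxy for acetyl gives a 2.7-fold higher number from compound 2 to compound 4 (0.43 log units; beyond the scatter) and is the first single change here that can be read as a step. The earlier compounds shown here offered no such pair, so only now is it plain that the group on this aromatic carbon, para to a large group, can move the number, in this case modestly and towards a weaker inhibitor. Nothing measured here gives a reason for this step.

From the compounds shown here alone, how an amine or a carboxylic acid at this place would compare with methoxy and acetyl remains open. Also open, going by these compounds, is whether a longer chain in the shared core would leave the size of this step unchanged.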